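This account rests on a few compounds, and the source may have more. Where it says the series, first, only, none or still open, it means among the compounds named here.

Compound 3 `COc1ccccc1/C=C/C(=O)c1ccc(OCC(=O)N[C@H]2CCOC2=O)cc1` is the weakest point fixed so far in a functional assay on MCF7 cells (Homo sapiens) for antiproliferative activity, read by MTT assay, with a stated time of 72 h; a lower number here means a stronger inhibitor, a higher number a weaker inhibitor: compound 3 gives only a limit of the assay, > 64000 nM, and no number. Compound 1 `O=C(COc1ccc(C(=O)/C=C/c2ccccc2Br)cc1)N[C@H]1CCOC1=O` gives 15300 nM in this assay, and compound 2 `CC(C)(C)c1ccc(/C=C/C(=O)c2ccc(OCC(=O)N[C@H]3CCOC3=O)cc2)cc1` gives 16400 nM; the pair differ by a 1.1-fold higher number from compound 1 to compound 2 (0.03 log units; within the scatter). Both sit well away from the limit held by compound 3, as an at least 4.1-fold higher number from compound 1 to compound 3 (0.62 log units; beyond the scatter) and an at least 3.9-fold higher number from compound 2 to compound 3 (0.59 log units; beyond the scatter) show.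

Compound 4 `O=C(COc1ccc(C(=O)/C=C/c2cccc(Br)c2)cc1)N[C@H]1CCOC1=O` carries 3-bromophenyl in place of 2-methoxyphenyl on a double-bonded chain carbon bound to a double-bonded chain carbon. This undoes the methoxy-for-bromo exchange of the step from compound 1 to compound 3, though the bromine now enters as 3-bromophenyl rather than the 2-bromophenyl of compound 1. The two measured steps that bear on it, an at least 4.1-fold higher number from compound 1 to compound 3 (0.62 log units; beyond the scatter) and an at least 3.9-fold higher number from compound 2 to compound 3 (0.59 log units; beyond the scatter), were both at least modest and both ran toward the limit; the return to a bromophenyl group is therefore expected to run the other way, giving a lower number for compound 4 than the limit held by compound 3, i.e. a step of about an at least 3.5-fold lower number from compound 3 to compound 4 (0.55 log units; beyond the scatter) in this assay. Compound 4 is expected to come in near 18000 nM, within 6000 nM to 60000 nM, close to where compound 1 and compound 2 stand.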

Compound 4, half-maximal inhibitory concentration: 28300 nM
For compound 4 the middle estimate is 1.6-fold (0.20 log units) below the measured one; the measured number falls inside the stated range.
By their numbers in this assay, from the lowest: compounds 1, 2 and 4 (each within the scatter of the next). At a limit, above all of these: compound 3.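

In this assay, 3-bromophenyl in place of 2-methoxyphenyl gives an at least 2.2-fold lower number from compound 3 to compound 4 (0.35 log units; beyond the scatter), so the step away from the limit does not rest on 2-bromophenyl alone. On a double-bonded chain carbon bound to a double-bonded chain carbon, 3-bromophenyl cannot be told apart from 2-bromophenyl, at a 1.8-fold higher number from compound 1 to compound 4 (0.27 log units; within the scatter), or from 4-(tert-butyl)phenyl, at a 1.7-fold higher number from compound 2 to compound 4 (0.24 log units; within the scatter). Compound 3 alone still holds a limit and no number: the limit of > 64000 nM in this assay, at which 1 of the 4 values shown sits.

Going by these compounds alone, how far compound 3 lies from the other three stays unfixed, and with only one methoxy compound, the methoxy group cannot be separated from its ring position. From the compounds shown here alone, whether a phenyl group carrying an amine or a carboxylic acid at this place would stand with compound 1, compound 2 and compound 4 or with compound 3 also stays open.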